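Swapping a Side Chain: Expected Cell Toxicity of Compound 4

This account rests on a few compounds, and the source may have more. Where it says the series, first, only, none or still open, it means among the compounds named here.

The measure here is an ADME assay on HepG2 2.2.15 cells (Homo sapiens) for cytotoxicity; on this read-out lower numbers stand for higher toxicity in this test and higher numbers for lower toxicity in this test. Compound 1 `Cc1cc(C(C)C)ccc1OC(c1ccc(Cl)cc1)c1cnc(NC(=O)OC(C)(C)C)s1` gives > 50000 nM, which is a limit of the test rather than a number. Compound 2 `CC(C)(C)OC(=O)Nc1ncc(C(Oc2ccc(Br)cc2)c2ccc(Cl)cc2)s1` gives > 50000 nM, again a limit. The step that the two limits leave unreadable from compound 1 to compound 2 therefore cannot be read. Compound 3 `Clc1ccc(C(Oc2ccc3cc(Br)ccc3c2)c2cnc(NCC3CCOCC3)s2)cc1` has no single number; in this assay compound 3 is recorded as "not toxic" (no number reported), so its standing can only be described as not toxic. Compound 4 `O=S(=O)(Nc1ncc(C(Oc2ccc3cc(Br)ccc3c2)c2ccc(Cl)cc2)s1)c1cccs1` differs from compound 3 by (thiophen-2-yl)sulfonyl in place of (oxan-4-yl)methyl on a nitrogen on an aromatic ring. Among the measured compounds shown here, no measured step touches this change, and the only evidence is the limit of > 50000 nM in this assay, at which 2 of the 3 values shown sit. Compound 4 is therefore expected to show 50000 nM, within a range from 20000 nM to 100000 nM, most likely reported again as a limit.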

Compound 4, half-maximal cytotoxic concentration: "not toxic" (no number reported)
Compound 4 has no reported number here; no gap can be computed for the estimate.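

Compound 3 and compound 4 each carry no number in this assay, so no step can be read between them. The compounds shown leave open whether (thiophen-2-yl)sulfonyl in place of (oxan-4-yl)methyl changes the cytotoxic concentration at all.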